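Butenamide in place of acrylamide on the fluorinated core

This account rests on a few compounds, and the source may have more. Where it says the series, first, only, none or still open, it means among the compounds named here.

Of the compounds shown here, two have numbers so far. Compound 2 `C=CC(=O)Nc1cc(Nc2nccc(-c3cn(C)c4ccc(F)cc34)n2)c(OC)cc1N(C)CCN(C)C` gives 254 nM in a functional assay on NCI-H1975 cells (Homo sapiens) for antiproliferative activity, read by MTT assay, with a stated time of 72 h (a lower number here means a stronger inhibitor, a higher number a weaker inhibitor), the lower of the two numbers shown. Within the data shown here, compound 1 `CC/C=C\C(=O)Nc1cc(Nc2nccc(-c3cn(C)c4ccccc34)n2)c(OC)cc1N(C)CCN(C)C` gives 3860 nM in this assay, a number beyond the scatter above that of compound 2; compound 1 carries the but-1-en-1-yl group and lacks the fluorine of compound 2, so the two differ in more than one respect and no single step between them can be read.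

Compound 3 `CC/C=C\C(=O)Nc1cc(Nc2nccc(-c3cn(C)c4ccc(F)cc34)n2)c(OC)cc1N(C)CCN(C)C` is not yet measured. It differs from compound 2 by but-1-en-1-yl in place of vinyl on a carbonyl carbon, while keeping the fluorine of compound 2. Among the measured compounds shown here, the only comparison at hand, compound 1 against compound 2, points toward a higher number for the butenyl amide, though the fluorine difference clouds it. A step of a 5.9-fold higher number from compound 2 to compound 3 (0.77 log units; beyond the scatter) upward is therefore expected. Compound 3 is estimated at 1500 nM, with a plausible span from 400 nM to 6000 nM.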

Compound 3, half-maximal inhibitory concentration: 2600 nM
Estimate against measurement, compound 3: 1.7-fold (0.24 log units) below; measured number inside the range.
By their numbers in this assay, from the lowest: compound 2; then compounds 3 and 1 (each within the scatter of the next).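

In this assay the amide end of the series can now be read as a single change: but-1-en-1-yl in place of vinyl on a carbonyl carbon, with the fluorine kept, gives a 10-fold higher number from compound 2 to compound 3 (1.01 log units; beyond the scatter), a large loss at this position. Among these compounds, the fluorine can also be read alone for the first time: with the but-1-en-1-yl amide in place, fluoro in place of hydrogen on an aromatic carbon gives a 1.5-fold lower number from compound 1 to compound 3 (0.17 log units; within the scatter), so this change cannot be told from scatter. Nothing measured here gives a reason for either step.

Going by these compounds, whether fluoro in place of hydrogen reads the same with the vinyl amide remains open. Also open, on these data alone, is how the loss tracks with what is carried on the vinyl end, for instance a propenyl or a dimethylaminomethyl group.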